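A few compounds are considered here, and "the series" means these few. Any claim that something is new, unique, unknown or untested is made for them only; others in the source may bear on it.

Compound 2 `O=C(CCCCCCNC(=O)C(O)(O)C(F)(F)F)Nc1ncc(-c2ccc(O)cc2)s1` is the weaker of the two measured compounds: in an assay on isolated protein for inhibition of protein deacetylase HDAC6 (Homo sapiens), read by chemiluminescence, with a stated time of 3 h (a higher number here means a weaker inhibitor, a lower number a stronger inhibitor), compound 2 gives 210000 nM, which is the highest of the two numbers on record. Among the compounds with values here, its nearest neighbour is compound 1 `COc1ccc(-c2cnc(NC(=O)CCCCCCNC(=O)C(O)(O)C(F)(F)F)s2)cc1`, and in this assay compound 1 gives 37000 nM; the only measured step, a 5.7-fold higher number from compound 1 to compound 2 (0.75 log units; beyond the scatter), is a hydrogen in place of a methyl on an oxygen on an aromatic ring and lies beyond the scatter.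

Compound 3 `O=C(CCCCCCNC(=O)C(O)(O)C(F)(F)F)Nc1ncc(-c2ccccc2)s1` is not yet measured. It differs from compound 2 by hydrogen in place of hydroxy on an aromatic carbon: the hydroxy leaves and a hydrogen enters, on an aromatic carbon of the six-membered carbon ring, para to a large group. Within the data shown here, the step from compound 1 to compound 2 bears on this only indirectly, since it exchanges one oxygen-bearing group for another, whereas here the oxygen is removed altogether; no measured step removes a substituent from this ring. Because a 5.7-fold higher number from compound 1 to compound 2 (0.75 log units; beyond the scatter) showed the hydroxy form to be the weaker of the two, the estimate for compound 3 is a modest step downward, a 3.0-fold lower number from compound 2 to compound 3 (0.48 log units; beyond the scatter), giving an expected value of 70000 nM within a range of 25000 nM to 200000 nM.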

Compound 3, half-maximal inhibitory concentration: 350000 nM
Compound 3: the middle estimate sits 5.0-fold (0.70 log units) below what was measured, outside the stated range (above it).
By their numbers in this assay, from the lowest: compound 1; then compounds 2 and 3 (each within the scatter of the next).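

In this assay, the new compound shows that, at this place para to a large group, the hydroxy and a plain hydrogen cannot be told apart: the step is a 1.7-fold higher number from compound 2 to compound 3 (0.22 log units; within the scatter). The earlier pair left open whether the gap between methoxy and hydroxy set methoxy apart or set hydroxy apart, and the new step, a 9.5-fold higher number from compound 1 to compound 3 (0.98 log units; beyond the scatter), points to the former, since compound 1 now lies beyond the scatter from both compound 2 and compound 3. Nothing in hand explains why the methoxy form stands apart in this way.

The three compounds leave open whether an ethoxy, a chlorine or an amine at this place would read with compound 1 or with compound 2 and compound 3, and so whether the separation is particular to methoxy. They also leave open whether it would persist with a shorter or longer chain, or with a hydroxamic acid at the end of the chain in place of the group all three compounds share there.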